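Swapping nitro for chloro on an antiproliferative series

The source may report more compounds than this note shows. Statements on the series, on what has been measured and on what is new or still open speak of the compounds shown alone.

Compound 1 `COc1ccc(C(=O)/C=C/c2ccc3ccccc3c2)c2c1C=CC(C)(C)O2`: 5820 nM
Compound 2 `CCN(CC)c1ccc(/C=C/C(=O)c2ccc(OC)c3c2OC(C)(C)C=C3)cc1`: 620 nM
Compound 3 `COc1ccc(C(=O)/C=C/c2ccc([N+](=O)[O-])cc2)c2c1C=CC(C)(C)O2`: 8880 nM

In a functional assay on HCT-116 cells (Homo sapiens) for antiproliferative activity, read by MTT assay, with a stated time of 24 h (on this read-out higher numbers stand for weaker inhibition and lower numbers for stronger inhibition), compound 3 gives 8880 nM. That number lies within the scatter of compound 1 at 5820 nM, while compound 2 stands far lower at 620 nM.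

Compound 4 `COc1ccc(C(=O)/C=C/c2ccc(Cl)cc2)c2c1C=CC(C)(C)O2` is built from compound 3 by one change: chloro in place of nitro on an aromatic carbon. This is chloro in place of nitro on an aromatic carbon.

Going by the values given here, the only measured step at that place is a 14-fold higher number from compound 2 to compound 3 (1.16 log units; beyond the scatter), with nitro in place of diethylamino. It is large, but it involves diethylamino, which compound 4 does not carry, so its size is not transferred here. No step beyond the scatter is expected in this assay. At most a small shift to a lower number is expected, with the value of compound 1, 5820 nM, as the nearest guide.

The expected change is a 1.6-fold lower number from compound 3 to compound 4 (0.21 log units; within the scatter). The estimate for compound 4 is 5500 nM, with an expected range of 2200 nM to 12000 nM.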

Compound 4, half-maximal inhibitory concentration: > 10000 nM
Compound 4: only a limit was reported (the forecaster's own chance of this, stated with the estimate: 3%); middle value at least 1.8-fold (0.25 log units) away from the limit.
By their numbers in this assay, from the lowest: compound 2; then compounds 1 and 3 (each within the scatter of the next). At a limit, above all of these: compound 4.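

In this assay compound 4 gives only a limit, not a number: the limit of > 10000 nM in this assay, at which 1 of the 4 values shown sits. Chloro in place of nitro, on the aromatic carbon para to a large group, gives an at least 1.1-fold higher number from compound 3 to compound 4 (0.05 log units; that floor lies within the scatter) and so does not separate the two groups, while the limit leaves the true size of the step unknown. Chloro in place of diethylamino gives an at least 16-fold higher number from compound 2 to compound 4 (1.20 log units; beyond the scatter), so at this position a second group besides nitro now stands clearly apart from diethylamino, where the earlier compounds offered only nitro for that comparison.

From the compounds shown here alone, what remains open is whether the low number of compound 2 is specific to diethylamino or is shared by other amines at this position, such as dimethylamino or a pyrrolidine. A methoxy or hydroxy group in the same place also remains untested among the compounds shown, so the reach of this contrast is not yet known.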